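The compounds below may be only part of what the source reports. "The series", "measured", "known", "first", "only" and "open" are said of these compounds alone.

Compound 1 `C=CCNC(=O)/C(C)=C(\C)c1ccc(C)cc1` stands level with compound 2 `C/C(C(=O)NC1CC1)=C(/C)c1ccc(C)cc1` in a toxicity assay on the whole organism (strain Icem-CET (SPF Caw)) for cytotoxicity, with Mus musculus as the target; on this read-out lower numbers stand for an effect already at smaller amounts and higher numbers for an effect only at larger amounts of compound: compound 1 gives 150 mg/kg, and compound 2 gives 150 mg/kg. Within the data shown here, the single measured step, no change at the digits printed from compound 1 to compound 2 (within the scatter), concerns the group on the amide-type nitrogen and lies within the scatter. Compound 3 `C=CCNC(=O)/C(C)=C(/C)c1ccc(C)cc1` differs from compound 1 as follows: the two compounds have the same atoms and bonds and differ only in configuration as drawn: 1 of 1 stereo elements differ; a double bond is drawn E in compound 1 and Z in compound 3. Among the measured compounds shown here, no measured step bears on a change in double-bond configuration, so the one flat step is the only guide. In this assay the step expected is no change at the digits printed from compound 1 to compound 3 (within the scatter), nothing beyond the scatter. Compound 3 is therefore estimated at 150 mg/kg, within a range from 75 mg/kg to 300 mg/kg.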

Compound 3, dose for half-maximal effect: 400 mg/kg
Compound 3: middle estimate off by 2.7-fold (0.43 log units), on the low side; the whole stated range lies below it.
By their numbers in this assay, from the lowest: compounds 1 and 2 (each within the scatter of the next); then compound 3.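

In this assay the double bond turns out to be a place where a change moves the number: the step is a 2.7-fold higher number from compound 1 to compound 3 (0.43 log units; beyond the scatter), whereas the change on the amide-type nitrogen gave no change at the digits printed from compound 1 to compound 2 (within the scatter). The step can be laid on the configuration alone, because nothing else separates the pair: the fact that compounds 1 and 3 differ only in the configuration as drawn. From the compounds shown here alone, it stays open whether the same change of configuration carries over to the cyclopropyl group of compound 2, and whether a longer chain or an amine on the amide-type nitrogen would keep this gap.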